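Methoxy addition on the aryl rings of a triene series

The source may report more compounds than this note shows. Statements on the series, on what has been measured and on what is new or still open speak of the compounds shown alone.

Compound 1, `COc1ccc(/C=C/[C@@](C)(/C=C/c2ccc(O)cc2)CCC=C(C)C)cc1`: in a functional assay on Raji cells (Homo sapiens) for cytotoxicity, with a stated time of 72 h (on this read-out higher numbers stand for an effect only at larger amounts of compound and lower numbers for an effect already at smaller amounts), compound 1 gives > 26000 nM, a limit of the assay.
Compound 2, `CC(C)=CCC[C@@](C)(/C=C/c1ccccc1)/C=C/c1ccc(O)cc1`: in this assay compound 2 gives > 26000 nM, again a limit of the assay.
Compound 3, `C=C[C@@](C)(/C=C/c1ccc(Nc2ccc(OC)cc2)cc1)CCC=C(C)C`: in this assay compound 3 gives > 26000 nM, also a limit of the assay.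

Among the compounds with values here, all three measured compounds sit at one and the same limit, (the limit of > 26000 nM in this assay, at which 3 of the 3 values shown sit), so no step among them can be read. The change from compound 2 to compound 1 is methoxy in place of hydrogen on an aromatic carbon; the step it made, a step that the two limits leave unreadable from compound 2 to compound 1, is left unreadable by the two limits. Compound 2 and compound 3 differ in their cores as well, and the difference between the two cores is not broken down here.

Compound 4, `C=C[C@@](C)(/C=C/c1ccc(Nc2ccc(OC)c(OC)c2)cc1)CCC=C(C)C`, is not yet measured in this assay. It arises from compound 3 by methoxy in place of hydrogen on an aromatic carbon. This is the same kind of change as that from compound 2 to compound 1, not the same change: there the entering group sits para to a large group, here it sits ortho to a methoxy group and meta to a large group.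

For compound 4 in this assay the expected value is 40000 nM, with an expected range from 15000 nM to 150000 nM. The expected step that the limit leaves unreadable from compound 3 to compound 4 is small and rests on (the limit of > 26000 nM in this assay, at which 3 of the 3 values shown sit), at which compound 3 itself sits. Most likely the assay will again report only a limit for compound 4.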

Compound 4, half-maximal effective concentration: > 26000 nM
Compound 4: only a limit was reported (the forecaster's own chance of this, stated with the estimate: 80%); the middle value lies beyond the limit too.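

No step can be read between compound 3 and compound 4 in this assay, as both compounds give only a limit: the limit of > 26000 nM in this assay, at which 4 of the 4 values shown sit.

The compounds shown leave open whether methoxy in place of hydrogen on an aromatic carbon changes the read-out in either pair, and at what amount, if any, any of the four compounds would show an effect in this assay.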